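From fluoro to trifluoromethoxy on a shared core

The source may hold more compounds than are shown below. What is called first, only, known or untested is meant among the compounds shown, and "the series" means these compounds.

Compound 1 `O=C(/C=C/c1cccc(F)c1)c1ccc(O)cc1`: 9150 nM
Compound 2 `O=C(/C=C/c1ccc(F)cc1)c1ccc(O)cc1`: > 10000 nM (a limit of the assay, not a number)

Within the data shown here, in a functional assay on RAW264.7 cells (Mus musculus) for inhibition, read by fluorescence, with stated times of 1 h, 24 h and 30 min (on this read-out lower numbers stand for stronger inhibition and higher numbers for weaker inhibition), compound 1 holds the only true number of the pair, 9150 nM. The entry for compound 2 is a limit and gives no number to compare with. Compound 3 `O=C(/C=C/c1cccc(OC(F)(F)F)c1)c1ccc(O)cc1` keeps the core of compound 1 and carries trifluoromethoxy in place of fluoro on an aromatic carbon, meta to a large group (trifluoromethoxy in place of fluoro on an aromatic carbon). Among the measured compounds shown here, no measured pair shows this exchange, so the expectation in this assay is loose: no step beyond the scatter, with a slight lean towards stronger inhibition. The estimated change is a 1.4-fold lower number from compound 1 to compound 3 (0.15 log units; within the scatter). Compound 3 is expected at 6500 nM. Its estimated range runs from 2000 nM to 10000 nM.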

Compound 3, half-maximal inhibitory concentration: > 10000 nM
Compound 3 was reported as a limit; the forecaster's own chance of this, stated with the estimate: 30%; middle value at least 1.5-fold (0.18 log units) away from the limit.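

In this assay compound 3 is reported as > 10000 nM, which is a limit of the assay and not a number. Trifluoromethoxy in place of fluoro on this aromatic carbon, meta to a large group, gives an at least 1.0-fold higher number from compound 1 to compound 3 (0.03 log units; that floor lies within the scatter), so the exchange shows no stronger inhibition at this place, while the true size of any loss stays unknown. The reading of this step is capped by the end of the measurable range, which now holds most of the series: the limit of > 10000 nM in this assay, at which 2 of the 3 values shown sit.

The compounds shown leave open how an amine or a carboxylic acid on this carbon would read against compound 1 at 9150 nM. They also leave open whether a smaller group such as chloro or methyl would keep a true number in this assay.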